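The source may hold more compounds than are shown below. What is called first, only, known or untested is meant among the compounds shown, and "the series" means these compounds.

Measured compounds:
compound 1, `CC1(C)N=C(N)N=C(N)N1c1ccc(CC(C(=O)Nc2ccc(S(=O)(=O)F)cc2)c2cccc3ccccc23)cc1`: in an assay on isolated protein for inhibition of Dihydrofolate reductase (Mus musculus) (on this read-out higher numbers stand for higher potency (the scale is a negative logarithm) and lower numbers for lower potency), compound 1 gives 6.24
compound 2, `COc1cccc(C(Cc2ccc(N3C(N)=NC(N)=NC3(C)C)cc2)C(=O)Nc2ccc(S(=O)(=O)F)cc2)c1`: compound 2 gives 6.46

Compound 2 holds the higher of the two numbers, with compound 1 nearest at a number 0.22 log units higher from compound 1 to compound 2 (within the scatter).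

Compound 3, `COc1ccccc1C(Cc1ccc(N2C(N)=NC(N)=NC2(C)C)cc1)C(=O)Nc1ccc(S(=O)(=O)F)cc1`, differs from compound 2 by 2-methoxyphenyl in place of 3-methoxyphenyl on a saturated chain carbon bound to a carbonyl carbon and a saturated chain carbon. Among the measured compounds shown here, the only measured step at that place is a number 0.22 log units higher from compound 1 to compound 2 (within the scatter), an exchange of a different aryl group that stayed within the scatter. Nothing here separates the two methoxyphenyl groups, so no step beyond the scatter is expected: a number 0.06 log units lower from compound 2 to compound 3 (within the scatter). For compound 3 the estimate is 6.4, range 5.9 to 6.9.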

Compound 3, logarithm of the reciprocal of the active concentration, log(1/C): 6.33
Beside the measured number, compound 3's estimate is 0.07 log units above it; the range from low to high includes it.
By their numbers in this assay, from the lowest: compounds 1, 3 and 2 (each within the scatter of the next).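

At the place on a saturated chain carbon bound to a carbonyl carbon and a saturated chain carbon, this assay shows a number 0.13 log units lower from compound 2 to compound 3 (within the scatter) for the exchange of 3-methoxyphenyl for 2-methoxyphenyl, so these two groups are not separated. The exchange of naphthalen-1-yl for 2-methoxyphenyl gives a number 0.09 log units higher from compound 1 to compound 3 (within the scatter) and likewise separates nothing, leaving all three aryl groups at this place within the scatter of one another. No supporting data explain this result.

Still open, as far as these compounds go, is whether cyclohexyl or a carboxylic acid at this place would give a step beyond the scatter in this assay.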